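The source may hold more compounds than are shown below. What is called first, only, known or untested is meant among the compounds shown, and "the series" means these compounds.

Measured compounds:
Compound 1 `Cc1ccc(/C=C2/S/C(=N/c3ccccc3)N(Cc3ccncc3)C2=O)cc1`: 49500 nM
Compound 2 `CN(C)c1ccc(/C=C2/S/C(=N/c3ccccc3)N(Cc3ccncc3)C2=O)cc1`: 122000 nM

In an ADME assay on HEK293 cells (Homo sapiens) for cytotoxicity, read by MTT assay, with a stated time of 48 h (a lower number here means a stronger inhibitor, a higher number a weaker inhibitor), compound 1 gives 49500 nM, the lowest of the two numbers measured; its nearest neighbour is compound 2, which gives 122000 nM. For the measured compounds named here, the one measured step, a 2.5-fold higher number from compound 1 to compound 2 (0.39 log units; beyond the scatter), shows that changing the substituent on the aryl group of the shared core moves the number only modestly, though beyond the scatter.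

Compound 3 `COc1ccc(OC)c(/C=C2/S/C(=N/c3ccccc3)N(Cc3ccncc3)C2=O)c1` has not been measured. It differs from compound 1 in one place: 2,5-dimethoxyphenyl in place of 4-methylphenyl on a double-bonded chain carbon bound to a double-bonded ring carbon. Going by the values given here, no measured pair shows this particular exchange, so the step from compound 1 to compound 2 is the only guide, and it suggests that a change on this aryl group shifts the number by a small amount, if at all. A small step toward a higher number, or none beyond the scatter, is therefore expected in this assay.

Compound 3 is expected to give about 60000 nM, within a range from 25000 nM to 150000 nM. This estimate means an expected step of a 1.2-fold higher number from compound 1 to compound 3 (0.08 log units; within the scatter).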

Compound 3, half-maximal inhibitory concentration: 80100 nM
Estimate against measurement, compound 3: 1.3-fold (0.13 log units) below, and the stated range covers the measured number.
By their numbers in this assay, from the lowest: compounds 1, 3 and 2 (each within the scatter of the next, the first and the last beyond it).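

In this assay, placing 2,5-dimethoxyphenyl on a double-bonded chain carbon bound to a double-bonded ring carbon gives two new steps, both within the scatter: one replaces 4-methylphenyl (a 1.6-fold higher number from compound 1 to compound 3 (0.21 log units; within the scatter)) and the other replaces 4-(dimethylamino)phenyl (a 1.5-fold lower number from compound 2 to compound 3 (0.18 log units; within the scatter)). The earlier compounds shown here showed only an exchange of one substituent on the aryl group, whereas this result shows that a change in the number and placement of substituents, here to a group of 10 heavy atoms with 2 hydrogen-bond acceptors, is read as no clear change from either earlier compound. For the compounds shown here, compound 3 therefore cannot be ordered against compound 1 or compound 2, and the only step beyond the scatter among the three remains the modest one (a 2.5-fold higher number from compound 1 to compound 2 (0.39 log units; beyond the scatter)). No measurement is available that bears on what lies behind these numbers.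

The compounds shown leave open whether a carboxylic acid or a primary amine on this aryl group would move the number further than these substituents do. They also leave open how the number responds to changes elsewhere, since the rest of the shared core is the same in all three compounds.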